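The compounds below may be only part of what the source reports. "The series", "measured", "known", "first", "only" and "open" are said of these compounds alone.

Compound 1 `NS(=O)(=O)c1ccccc1-n1nc(C(F)(F)F)c2c1C(=O)N(c1ccc(-c3ccccc3CN3CC[C@@H](O)C3)cc1)CC2` gives 9.4 h in an in vivo ADME assay on the whole organism for metabolic stability, with Canis familiaris (Canis lupus familiaris) as the target (on this read-out higher numbers stand for a longer-lived compound and lower numbers for a shorter-lived compound), the lowest of the two numbers available; its nearest neighbour, compound 2 `CN(C)Cc1ccccc1-c1ccc(N2CCc3c(C(F)(F)F)nn(-c4ccccc4S(N)(=O)=O)c3C2=O)cc1`, gives 11.6 h in this assay. For the measured compounds named here, the only measured step, a 1.2-fold higher number from compound 1 to compound 2 (0.09 log units; within the scatter), changes another part of the molecule and stays within the scatter. Compound 3 `NC(=O)c1cccc(-n2nc(C(F)(F)F)c3c2C(=O)N(c2ccc(-c4ccccc4CN4CC[C@@H](O)C4)cc2)CC3)c1` departs from compound 1 in a different way: 3-carbamoylphenyl in place of 2-sulfamoylphenyl on an aromatic nitrogen. Going by the values given here, no measured step touches this aromatic nitrogen, so the change has no direct precedent among the measured compounds; the one known step shows only that the shared core gave similar half-lives when the group on the saturated chain carbon was exchanged. Among the compounds with values here, with no precedent, the expected step of a 1.3-fold lower number from compound 1 to compound 3 (0.13 log units; within the scatter) is small, in no settled direction, and carries a wide range. Compound 3 is estimated at 7 h in this assay, between 3 h and 18 h.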

Compound 3, half-life: 7.2 h
Compound 3: middle estimate off by 1.0-fold (0.01 log units), on the low side, and the stated range covers the measured number.
By their numbers in this assay, from the lowest: compounds 3, 1 and 2 (each within the scatter of the next).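

For the compounds shown here, at this aromatic nitrogen, the exchange of 2-sulfamoylphenyl for 3-carbamoylphenyl gives a 1.3-fold lower number from compound 1 to compound 3 (0.12 log units; within the scatter) in this assay, the first measured step at this place. The half-life of the compound therefore does not depend measurably on keeping 2-sulfamoylphenyl here, at least against this one replacement. The exchange alters both the attached group and its name-given position on the phenyl ring, so this single step cannot separate the two changes, and nothing available accounts for the result.

The compounds shown leave open whether a carboxylic acid or a nitrile in place of the carbamoyl group would also keep the half-life within the scatter. They also leave open how 3-carbamoylphenyl behaves when paired with the dimethylamino group of compound 2.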